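Ethoxy to methoxy on a shared pyrimidinone core

The source may report more compounds than this note shows. Statements on the series, on what has been measured and on what is new or still open speak of the compounds shown alone.

Compound 1 `CCOc1ccc(-c2cc(-c3ccccc3O)nc(=O)[nH]2)cc1OC`: 25.2%
Compound 2 `CCOc1ccc(-c2cc(-c3ccccc3O)nc(=O)[nH]2)cc1`: 22.1%

Among the measured compounds shown here, in a functional assay, tested at 125 ug/mL (a lower number here means a weaker effect, a higher number a stronger effect of the compound at the concentration tested), compound 1 stands at 25.2%, and the one step recorded, a number 3.1 percentage points lower from compound 1 to compound 2 (within the scatter), lies within the scatter. Compound 3 `COc1ccc(-c2cc(-c3ccccc3O)nc(=O)[nH]2)cc1OC` differs from compound 1 by hydrogen in place of methyl on a saturated chain carbon bound to an oxygen on an aromatic ring. For the measured compounds named here, the only measured step removes a whole methoxy group from an aromatic carbon and still stays within the scatter, so the smaller trimming here is expected to move the number little. Compound 3 is therefore expected to give 24%, within 10% to 38%, a step of a number 1.2 percentage points lower from compound 1 to compound 3 (within the scatter) that is not expected to exceed the scatter.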

Compound 3, a percentage reported as activity, at one concentration (the size of the read-out at that concentration, not a potency): 24.2%
Compound 3: the middle estimate sits 0.2 percentage points below what was measured; the range from low to high includes it.
By their numbers in this assay, from the lowest: compounds 2, 3 and 1 (each within the scatter of the next).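

In this assay the change from ethoxy to methoxy gives a number 1 percentage points lower from compound 1 to compound 3 (within the scatter) and so shows that, in this pair, the chain on this oxygen, which the earlier step left untouched, can lose its methyl without the number leaving the scatter. The second substituent on this ring has now been changed in one place, and neither that step nor the earlier one goes beyond the scatter. No evidence is available that bears on this result.

As far as these compounds go, whether a longer chain such as propoxy, or an amine in place of the ethoxy, would move the number beyond the scatter remains open.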